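This account rests on a few compounds, and the source may have more. Where it says the series, first, only, none or still open, it means among the compounds named here.

Of the compounds shown here, two have been measured so far in an ADME assay for pharmacokinetics, read by HPLC; on this read-out lower numbers stand for a shorter-lived compound and higher numbers for a longer-lived compound. Compound 1 `C/C1=C\[C@@H](O)C(=O)/C=C/C=C/c2csc(n2)[C@@H](C)N2C(=O)C[C@@]([C@@](C)(O)C(=O)SCC(=O)OC(C)(C)C)(CC1)[S+]2[O-]` gives > 24 h, and this reading is a limit of the assay, not a number. Within the data shown here, compound 2 `COC1(O[C@@H]2/C=C(\C)CC[C@]3([C@@](C)(O)C(=O)SCc4oc(=O)oc4C)CC(=O)N([C@H](C)c4nc(cs4)/C=C/C=C/C2=O)[S+]3[O-])CCOCC1` gives 18 h, which is the only true number available in this assay. The two compounds differ in more than one place, so their readings cannot be tied to any single structural change.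

Compound 3 `C/C1=C\[C@@H](O[C@H]2CCCCO2)C(=O)/C=C/C=C/c2csc(n2)[C@@H](C)N2C(=O)C[C@@]([C@@](C)(O)C(=O)SCc3oc(=O)oc3C)(CC1)[S+]2[O-]` differs from compound 2 in one place. On an oxygen on a saturated carbon, oxan-2-yl stands in place of 4-methoxyoxan-4-yl (oxan-2-yl in place of 4-methoxyoxan-4-yl on an oxygen on a saturated carbon). Among the measured compounds shown here, no measured pair shows what a change of this kind does in this assay, so the expectation is anchored on compound 2 and its 18 h. With nothing to suggest a direction, no shift beyond the usual scatter is expected. The estimated size of no change at the digits printed from compound 2 to compound 3 (within the scatter) reflects this. Compound 3 is expected to read about 18 h, with an estimated range from 9 h to 30 h, and a reading reported only as a limit cannot be ruled out.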

Compound 3, half-life: 30 h
Compound 3: the middle estimate sits 1.7-fold (0.22 log units) below what was measured; the measured number falls inside the stated range.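

Among these compounds, this pair gives the first step in this assay between compounds that differ in one place: with oxan-2-yl in place of 4-methoxyoxan-4-yl on an oxygen on a saturated carbon, the read-out shows a 1.7-fold higher number from compound 2 to compound 3 (0.22 log units; within the scatter). On this single pair, the two groups cannot be told apart at this position, even though the entering group has fewer heavy atoms and hydrogen-bond acceptors and brings a defined stereocentre. Compound 1 stays a limit of the assay and not a number, and it forms no step with either of the others: the limit of > 24 h in this assay, at which 1 of the 3 values shown sits.

The compounds shown leave open whether this result holds for groups on this oxygen that are unlike these two six-membered rings, such as a simple methyl ether or an acetyl ester. They also leave open what the free hydroxyl of compound 1 contributes on its own, since compound 1 differs from compound 2 in more than one place and its reading cannot be tied to that group.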